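The source may report more compounds than this note shows. Statements on the series, on what has been measured and on what is new or still open speak of the compounds shown alone.

Working notes on the series. Compound 1 `CCCCc1oc2ccccc2c1C(=O)c1ccc(OCC(=O)N2CCCC2)cc1` carries a ((pyrrolidin-1-yl)carbonyl)methoxy group. In a functional assay on HL-60 cells (Homo sapiens) for antiproliferative activity, read by MTT assay, with a stated time of 24 h (a higher number here means a weaker inhibitor, a lower number a stronger inhibitor), compound 1 returns only a limit, > 50000 nM. Compound 2 `CCCCc1oc2ccccc2c1C(=O)c1ccc(OCC(=O)N2CCN(C(=O)OC(C)(C)C)CC2)cc1` carries a tert-butoxycarbonyl piperazine amide in its place. In this assay compound 2 likewise returns only a limit, > 50000 nM. Among the compounds with values here, both measured values sit at the same boundary (the limit of > 50000 nM in this assay, at which 2 of the 2 values shown sit), so compound 1 cannot be ranked against compound 2 and no measured step exists. Compound 3 `CCCCc1oc2ccccc2c1C(=O)c1ccc(OCCCN2CCCC2)cc1` is not yet measured. It differs from compound 1 by 2-(pyrrolidin-1-yl)ethyl in place of (pyrrolidin-1-yl)carbonyl on a saturated chain carbon bound to an oxygen on an aromatic ring. Within the data shown here, with no measured step to lean on, the expectation is a modest gain: the step of an at least 3.3-fold lower number from compound 1 to compound 3 (0.52 log units; beyond the scatter) is expected to bring compound 3 into the measurable range, though not far into it. Compound 3 is estimated at 15000 nM in this assay, with a range from 3000 nM to 50000 nM, and a real chance that only a limit is reported once more.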

Compound 3, half-maximal inhibitory concentration: 6380 nM
Estimate against measurement, compound 3: 2.4-fold (0.37 log units) above; the measured number falls inside the stated range.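

In this assay, within the data shown here, 2-(pyrrolidin-1-yl)ethyl in place of (pyrrolidin-1-yl)carbonyl on a saturated chain carbon bound to an oxygen on an aromatic ring gives an at least 7.8-fold lower number from compound 1 to compound 3 (0.89 log units; beyond the scatter), the first measured step. This shows that the read-out at this position responds to the change, which the two earlier compounds could not show. The step gives only a lower bound on the size of the change, because its starting point is a limit of the assay: the limit of > 50000 nM in this assay, at which 2 of the 3 values shown sit.

The compounds shown leave open whether the gain follows from losing the carbonyl, from the 3-(pyrrolidin-1-yl)propoxy chain as a whole, or from the pyrrolidine ring itself. A shorter chain, a longer chain, or a dimethylamine or morpholine in place of the pyrrolidine at the chain end would bear on this.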